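The compounds below may be only part of what the source reports. "The series", "measured", "known", "first", "only" and "open" are said of these compounds alone.

Measured so far:
Compound 1, `Cc1nc(C)c(/C=C/C(=O)/C=C/c2cccc(O)c2)nc1C`, 4300 nM
Compound 2, `Cc1nc(C)c(/C=C/C(=O)/C=C/c2ccc(O)cc2)nc1C`, 4010 nM
Compound 3, `COc1cccc(/C=C/C(=O)/C=C/c2nc(C)c(C)nc2C)c1`, 3300 nM

All three were tested in a functional assay on A549 cells (Homo sapiens) for antiproliferative activity, read by MTT assay, with a stated time of 72 h (a higher number here means a weaker inhibitor, a lower number a stronger inhibitor), and their numbers lie within the usual scatter of one another. Compound 1 and compound 2 share the same atoms joined differently: 4-hydroxyphenyl in place of 3-hydroxyphenyl on a double-bonded chain carbon bound to a double-bonded chain carbon. The step was a 1.1-fold lower number from compound 1 to compound 2 (0.03 log units; within the scatter). Compound 1 and compound 3 differ by methyl in place of hydrogen on an oxygen on an aromatic ring, and that step was a 1.3-fold lower number from compound 1 to compound 3 (0.11 log units; within the scatter).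

Compound 4, `COc1ccc(/C=C/C(=O)/C=C/c2nc(C)c(C)nc2C)cc1`, has not yet been measured in this assay. It differs from compound 2 by methyl in place of hydrogen on an oxygen on an aromatic ring. Within the data shown here, this is the same change as the one from compound 1 to compound 3, at a place described in the same words, so the earlier step is the only guide. On that basis the step from compound 2 to compound 4 is expected to be about a 1.3-fold lower number from compound 2 to compound 4 (0.11 log units; within the scatter), which rests on a 1.3-fold lower number from compound 1 to compound 3 (0.11 log units; within the scatter) and stays within the scatter. Compound 4 is therefore estimated at 3100 nM in this assay, with an expected range from 1500 nM to 6000 nM.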

Compound 4, half-maximal inhibitory concentration: 3500 nM
Compound 4: middle estimate off by 1.1-fold (0.05 log units), on the low side, within the range that was stated.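

In this assay, the change from hydroxy to methoxy on the aromatic ring gave a 1.1-fold lower number from compound 2 to compound 4 (0.06 log units; within the scatter). Set beside the earlier step, the same change reads alike on the two cores: the same change on two cores in this assay, a 1.3-fold lower number (0.11 log units; within the scatter) from compound 1 to compound 3 and a 1.1-fold lower number (0.06 log units; within the scatter) from compound 2 to compound 4, 1.1-fold (0.06 log units) apart, within the scatter of two such steps. Among these compounds, this agreement shows that, in both pairs, the change left the number within the scatter, but with only two pairs and neither step beyond the scatter, it does not show that the methoxy group has a real effect of its own, or that the result would carry over to a core other than those of compound 1 and compound 2.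

The aromatic ring substituents shown are limited to hydroxy and methoxy, so the compounds leave open what an amine, a carboxylic acid or a longer alkoxy chain at these places would do in this assay. They also leave open whether a halogen such as fluorine or chlorine there would move the number beyond the scatter, and whether the agreement between these steps would hold for such groups.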